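From 2-iodophenyl to 3-aminophenyl: an open step

The source may hold more compounds than are shown below. What is called first, only, known or untested is meant among the compounds shown, and "the series" means these compounds.

compound 1 `COC(=O)C1=C(C)N=C(C)/C(=C(\O)OC)C1c1cc(Cl)cc(Cl)c1` gives 93.3 nM 
compound 2 `COC(=O)C1=C(C)N=C(C)/C(=C(\O)OC)C1c1ccccc1I` gives 46.8 nM 

In a functional assay (muscle tissue) with Cavia porcellus as the target (on this read-out lower numbers stand for an effect already at smaller amounts and higher numbers for an effect only at larger amounts of compound), compound 2 gives 46.8 nM and stands level with compound 1 at 93.3 nM once the usual scatter is allowed for. The two cannot be ranked. The next compound, compound 3 `COC(=O)C1=C(C)N=C(C)/C(=C(\O)OC)C1c1cccc(N)c1`, has not yet been measured. It differs from compound 2 in one place, (3-aminophenyl in place of 2-iodophenyl on a saturated ring carbon), and in words this is 3-aminophenyl in place of 2-iodophenyl on a saturated ring carbon.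

Going by the values given here, only one measured step bears on this change, and it is a 2.0-fold lower number from compound 1 to compound 2 (0.30 log units; within the scatter) with both of its compounds carrying halogen atoms on the phenyl ring. Among the compounds with values here, it is a weak guide, as neither compound has an amino group and only two values are available. A moderate move towards a higher number in this assay is expected, but with little certainty. The expected change is a 5.3-fold higher number from compound 2 to compound 3 (0.73 log units; beyond the scatter) in this estimate. For compound 3 the estimated value is 250 nM as the middle of an expected range from 50 nM to 1200 nM for now.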

Compound 3, half-maximal effective concentration: 2000 nM
Compound 3: middle estimate off by 8.0-fold (0.90 log units), on the low side, and the stated range ends below it.
By their numbers in this assay, from the lowest: compounds 2 and 1 (each within the scatter of the next); then compound 3.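

This position does not accept every substituted phenyl alike. In this assay, 3-aminophenyl in place of 2-iodophenyl gives a 43-fold higher number from compound 2 to compound 3 (1.63 log units; beyond the scatter) and, set against the 3,5-dichlorophenyl group, gives a 21-fold higher number from compound 1 to compound 3 (1.33 log units; beyond the scatter) while the two halogen-bearing compounds stay within the scatter of each other. The large step from compound 2 comes with no change in size as counted here, since both groups have 7 heavy atoms and one aromatic ring of carbon only, so that count does not separate them; what differs is iodine leaving, nitrogen entering with a hydrogen-bond donor and acceptor, and the place of the group on the phenyl ring. Nothing shown here explains why the number rises so far.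

The step changes the atom and its place on the phenyl ring together, so the compounds shown cannot say which of the two matters. A 2-aminophenyl or 3-iodophenyl group would separate them, while a plain phenyl, 3-hydroxyphenyl or 3-methoxyphenyl group would show whether the higher number is tied to the amine itself or to the loss of halogen.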